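Cyclohexenyl enyne retinoid acids: binding to retinoic acid receptor alpha

This account rests on a few compounds, and the source may have more. Where it says the series, first, only, none or still open, it means among the compounds named here.

Measured compounds:
compound 1 `CC1(C)CCC(C)(C)c2cc(C/C=C/c3ccc(C(=O)O)cc3)ccc21`, 36 nM
compound 2 `CCc1ccc(C2=C(/C=C/C#Cc3ccc(C(=O)O)cc3)C(C)(C)CCC2)cc1`, 136 nM

In an assay on isolated protein for binding affinity to retinoic acid receptor alpha (Homo sapiens), read by radioligand binding (on this read-out higher numbers stand for weaker binding and lower numbers for tighter binding), compound 1 gives 36 nM and compound 2 gives 136 nM. Compound 2 therefore has the highest of the two numbers; the gap to compound 1 lies beyond the scatter, so compound 2 binds less tightly than compound 1.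

Compound 3 `CC1=C(/C=C/C#Cc2ccc(C(=O)O)cc2)C(C)(C)CCC1` differs from compound 2 by methyl in place of 4-ethylphenyl on a double-bonded ring carbon. For the measured compounds named here, no step between measured compounds covers this change, so there is no measured precedent. The group that leaves is large and the group that enters is small, and the expectation is a step towards weaker binding in this assay, beyond the scatter, estimated as a 3.7-fold higher number from compound 2 to compound 3 (0.57 log units; beyond the scatter). Compound 3 is expected to give 500 nM in this assay, within a range from 150 nM to 2000 nM.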

Compound 3, dissociation constant: 135 nM
The estimate for compound 3 lay 3.7-fold (0.57 log units) above the measured number, outside the stated range (below it).
By their numbers in this assay, from the lowest: compound 1; then compounds 3 and 2 (each within the scatter of the next).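

Placing methyl in place of 4-ethylphenyl on a double-bonded ring carbon gives, in this assay, a 1.0-fold lower number from compound 2 to compound 3 (0.00 log units; within the scatter). For the compounds shown here, at this position, a group of 8 heavy atoms with a six-membered aromatic ring and a single methyl therefore cannot be told apart on this read-out, which the earlier compounds, joined by no single-place step, could not show. Nothing at hand explains this match between the two groups.

From the compounds shown here alone, whether other groups at this place, such as an unsubstituted phenyl, an ethyl, an amine or a carboxylic acid, would also read level with these two remains open. This comparison rests on a single pair, so it cannot show whether the same match would hold on the core of compound 1.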